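The source may hold more compounds than are shown below. What is called first, only, known or untested is meant among the compounds shown, and "the series" means these compounds.

The measurements come from a functional assay on K562 cells (Homo sapiens) for cytotoxicity, read by MTT assay, with a stated time of 72 h; a higher number here means a weaker inhibitor, a lower number a stronger inhibitor. Compound 1 `COc1ccc(NC(=O)COC(=O)/C=C/c2cc(OC)c(OCc3ccc(Cl)c(Cl)c3)c(OC)c2)cc1` and compound 2 `COc1cc(/C=C/C(=O)OCC(=O)Nc2ccc(Cl)cc2)cc(OC)c1OCc1ccc(Cl)c(Cl)c1` share one core and differ in a single place. For compound 1 this assay reports only a limit, > 200000 nM, and not a number. For compound 2 the result is likewise a limit, > 200000 nM. The change between them is methoxy in place of chloro on an aromatic carbon, yet the step that the two limits leave unreadable from compound 2 to compound 1 cannot be sized because the limit of > 200000 nM in this assay, at which 2 of the 3 values shown sit, covers both of its ends.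

Compound 3 `O=C(COC(=O)/C=C/c1ccc(O)c(O)c1)Nc1ccc(Cl)cc1` is built on another core; how its core differs from that of compound 2 is not broken down here. In this assay, among the measured compounds shown here, compound 3 gives 99400 nM, the only number among the three results so far.

Compound 4 `COc1ccc(NC(=O)COC(=O)/C=C/c2ccc(O)c(O)c2)cc1` is not yet measured. For the measured compounds named here, it differs from compound 3 by methoxy in place of chloro on an aromatic carbon, the same change, at the same place, as the one from compound 2 to compound 1. That measured example, however, gives no size to carry over, so the expectation rests on compound 3 alone, whose value of 99400 nM is the only anchor. The step of a 1.2-fold higher number from compound 3 to compound 4 (0.08 log units; within the scatter) is therefore expected to be small. Compound 4 is estimated at 120000 nM, with a likely range from 50000 nM to 300000 nM. Given where the two related results sit, a limit rather than a number is quite possible for compound 4.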

Compound 4, half-maximal inhibitory concentration: 79100 nM
Compound 4: middle estimate off by 1.5-fold (0.18 log units), on the high side; measured number inside the range.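

In this assay, replacing the 4-chlorophenyl of compound 3 with the 4-methoxyphenyl of compound 4 gives a 1.3-fold lower number from compound 3 to compound 4 (0.10 log units; within the scatter), so on this core the change has no effect that can be told apart from the ordinary spread of repeated measurements. The same change on the other core, from compound 2 to compound 1, cannot be read, because compound 1 and compound 2 each give a limit and not a number: the limit of > 200000 nM in this assay, at which 2 of the 4 values shown sit. The series therefore offers one readable example of this change, which shows that it is tolerated on the core of compound 3 but cannot show whether it would behave the same way on the core of compound 2, so nothing can yet be said about carrying it from one core to another.

The compounds shown leave open how a group of another kind, such as an amine or a carboxylic acid, would fare in this assay at this place on the ring, since only chloro and methoxy appear there. They also leave open which part of the difference between the two cores matters, as that difference is not broken down into single changes here.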